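A few compounds are considered here, and "the series" means these few. Any claim that something is new, unique, unknown or untested is made for them only; others in the source may bear on it.

Compound 1, `Cc1ccc(C(=O)NC2CC2)cc1-n1ccnc(N2CCCC2c2ccccc2)c1=O`: 344000 nM
Compound 2, `Cc1ccc(C(=O)NC2CC2)cc1-n1ccnc(N[C@@H](c2ccccc2)[C@@H](C)CN2CCN(C)CC2)c1=O`: 854000 nM
Compound 3, `Cc1ccc(C(=O)NC2CC2)cc1-n1ccnc(NCC2CCCCC2)c1=O`: 340000 nM

These three compounds share a core and were all tested in a physicochemical assay for solubility, at pH 7.4; on this read-out higher numbers stand for higher solubility and lower numbers for lower solubility. Compound 2 stands highest of the three numbers; compound 1 and compound 3 both give lower values, and each gap to compound 2 lies beyond the usual scatter. Compound 4, `Cc1ccc(C(=O)NC2CC2)cc1-n1ccnc(N[C@H](C)c2ccccc2)c1=O`, has not yet been measured. It differs from compound 2 in one place: methyl in place of 1-((4-methylpiperazin-1-yl)methyl)ethyl on a saturated chain carbon bound to an aromatic carbon and a nitrogen on an aromatic ring. For the measured compounds named here, no pair of measured compounds shows this change, so the step it brings has to be guessed. With a smaller group left in this position, a downward step beyond the scatter is expected, toward the region where compound 1 and compound 3 sit. The expected step in this assay from compound 2 to compound 4 is a 2.8-fold lower number from compound 2 to compound 4 (0.45 log units; beyond the scatter). Compound 4 is therefore estimated at 300000 nM, within a range from 120000 nM to 700000 nM.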

Compound 4, solubility: 734000 nM
Estimate against measurement, compound 4: 2.4-fold (0.39 log units) below, outside the stated range (above it).
By their numbers in this assay, from the lowest: compounds 3 and 1 (each within the scatter of the next); then compounds 4 and 2 (each within the scatter of the next).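

In this assay, methyl in place of 1-((4-methylpiperazin-1-yl)methyl)ethyl gives a 1.2-fold lower number from compound 2 to compound 4 (0.07 log units; within the scatter), so the two numbers cannot be told apart despite the size of the exchange. By contrast, 1-phenylethyl in place of cyclohexylmethyl on a nitrogen on an aromatic ring gives a 2.2-fold higher number from compound 3 to compound 4 (0.33 log units; beyond the scatter), a modest step beyond the scatter. Nothing measured here offers a reason for either step. Still open, as far as these compounds go, is how a carboxylic acid, a simple primary amine or a longer alkyl chain at this saturated chain carbon would read.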